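Removing the carboxy group from a thiophene series: a second trial

This account rests on a few compounds, and the source may have more. Where it says the series, first, only, none or still open, it means among the compounds named here.

Compound 1 `COc1ccc(-c2sc(C(=O)O)cc2-c2cc(OC)c(OC)c(OC)c2)cc1` is the point of departure of this set. In a functional assay on HT-1080 cells (Homo sapiens) for antiproliferative activity, read by MTT assay, with a stated time of 72 h (a higher number here means a weaker inhibitor, a lower number a stronger inhibitor), compound 1 gives 6770 nM. Compound 2 `COc1cc(-c2cc(C(=O)O)sc2-c2ccc3ccccc3c2)cc(OC)c1OC` differs from compound 1 only in the group on one ring carbon, where (naphthalen-2-yl in place of 4-methoxyphenyl on an aromatic carbon); in this assay compound 2 gives 13400 nM, and the step is a 2.0-fold higher number from compound 1 to compound 2 (0.30 log units; within the scatter). Compound 3 `COc1ccc(-c2sccc2-c2cc(OC)c(OC)c(OC)c2)cc1` keeps the core of compound 1 but has hydrogen in place of carboxy on an aromatic carbon; in this assay compound 3 gives 4590 nM, so that the step is a 1.5-fold lower number from compound 1 to compound 3 (0.17 log units; within the scatter).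

Compound 4 `COc1cc(-c2ccsc2-c2ccc3ccccc3c2)cc(OC)c1OC` has not been measured. It stands to compound 2 as compound 3 stands to compound 1: hydrogen in place of carboxy on an aromatic carbon. The surroundings are not identical, for in the earlier change the ring atom two ring bonds away bears a 4-methoxyphenyl group, whereas here that ring atom bears a naphthalen-2-yl group, so the two changes are the same kind of change rather than the same change.

Within the data shown here, with only one earlier example of this kind of change, the expectation for compound 4 rests on the step from compound 1 to compound 3, which is within the scatter, and on the value of compound 2. The step from compound 2 to compound 4 in this assay is expected to be a 1.5-fold lower number from compound 2 to compound 4 (0.17 log units; within the scatter), placed beside a 1.5-fold lower number from compound 1 to compound 3 (0.17 log units; within the scatter). Compound 4 is therefore estimated at 9000 nM, with a likely range from 4000 nM to 25000 nM.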

Compound 4, half-maximal inhibitory concentration: 5430 nM
Compound 4: middle estimate off by 1.7-fold (0.22 log units), on the high side, within the range that was stated.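

In this assay, putting hydrogen in place of carboxy on the core that bears the naphthalen-2-yl group gives a 2.5-fold lower number from compound 2 to compound 4 (0.39 log units; beyond the scatter), so on this core the removal of the carboxy group is a step that can be read beyond the scatter, whereas on the core of compound 1 it could not. That contrast between the two cores should not be pressed, however, since the two steps themselves do not separate: the same change on two cores in this assay, a 1.5-fold lower number (0.17 log units; within the scatter) from compound 1 to compound 3 and a 2.5-fold lower number (0.39 log units; beyond the scatter) from compound 2 to compound 4, 1.7-fold (0.22 log units) apart, within the scatter of two such steps The result therefore fits the change carrying over from one core to the other, but it rests on a single pair of compounds on each core, and it does not show that the change is truly larger on one core, why the step has the size it has, or that it would hold on any third core.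

The compounds shown leave open what other groups would do on the same aromatic carbon next to the ring sulfur, such as a methyl ester, a primary amide or an aminomethyl group. They also leave open how the change would behave with a ring other than 4-methoxyphenyl or naphthalen-2-yl on the shared core, for instance a 4-chlorophenyl or an indol-5-yl group.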